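The compounds below may be only part of what the source reports. "The series", "measured", "known", "first", "only" and "open" are said of these compounds alone.

Series notes. Compound 1 `COc1cccc(C(=O)Nc2cc(-c3ccccc3)nn2-c2ccccc2)c1` and compound 2 `O=C(Nc1cc(-c2ccccc2)nn1-c1ccccc1)c1cccc(C(F)(F)F)c1` share one core and differ only in the group carried on one aromatic carbon. Going by the values given here, in a functional assay on cells for positive allosteric modulation of metabotropic glutamate receptor 5 (Rattus norvegicus), read by calcium flux (a higher number here means that more compound is needed for the effect, a lower number that less compound is needed), compound 1 gives 102 nM, and compound 2 gives 228 nM; the single measured step, a 2.2-fold higher number from compound 1 to compound 2 (0.35 log units; beyond the scatter), is a modest rise that lies beyond the scatter. Compound 2 therefore stands at the higher of the two numbers, with compound 1 as its nearest neighbour.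

Compound 3 `O=C(Nc1cc(-c2ccccc2)nn1-c1ccccc1)c1cccc([N+](=O)[O-])c1` has not yet been run. It differs from compound 2 by nitro in place of trifluoromethyl on an aromatic carbon; cut one bond further out, the same difference reads 3-(trifluoromethyl)phenyl to 3-nitrophenyl. Among the compounds with values here, no measured step covers this exchange directly. Within the data shown here, the only step available, a 2.2-fold higher number from compound 1 to compound 2 (0.35 log units; beyond the scatter), concerns the same aromatic carbon but a different pair of groups, and it moved the number only modestly. The expectation for compound 3 in this assay is accordingly a step of about a 1.1-fold lower number from compound 2 to compound 3 (0.06 log units; within the scatter), with no direction that can be called beyond the scatter. Compound 3 is estimated at 200 nM, with a range from 60 nM to 700 nM.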

Compound 3, half-maximal effective concentration: 39 nM
For compound 3 the middle estimate is 5.1-fold (0.71 log units) above the measured one, outside the stated range (below it).
By their numbers in this assay, from the lowest: compound 3; then compound 1; then compound 2.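

At this position, on an aromatic carbon meta to a large group, the earlier pair showed only a rise on leaving methoxy; in this assay the exchange of trifluoromethyl for nitro gives a 5.8-fold lower number from compound 2 to compound 3 (0.77 log units; beyond the scatter) and places compound 3 lowest of the three. Against the methoxy compound the change is a 2.6-fold lower number from compound 1 to compound 3 (0.42 log units; beyond the scatter) and so runs opposite to the step to trifluoromethyl, which means that this one carbon can move the number either way from methoxy in this small set. No supporting data on hand bear on the reason for these steps.

The three groups do not show whether the low number is particular to nitro or would also be reached by other groups on the same carbon, such as a nitrile, an amine or a carboxylic acid. Also open, going by these compounds, is whether nitro gives a comparable number on another carbon of the same ring, and whether the order of the three groups holds when the rest of the shared core is changed.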